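The compounds below may be only part of what the source reports. "The series", "measured", "known", "first", "only" and "open" are said of these compounds alone.

Measured compounds:
- compound 1 `COc1ccc(/C=C/C=C/C(=O)c2cc(Cl)ccc2O)cc1`: "not active" (no number reported)
- compound 2 `COc1ccc(/C=C/C(O)=C/C(=O)c2c(O)cccc2OC)cc1OC`: 40%

Among the compounds with values here, in an in vitro assay on cells for inhibition of Amine oxidase [flavin-containing] A (Homo sapiens), read by Amplex Red, with a stated time of 15 min, tested at 100 uM (on this read-out higher numbers stand for more inhibition at the one concentration tested (going by the name of the read-out) and lower numbers for less inhibition), compound 2 gives 40%, and this is the only number in the set. Within the data shown here, compound 1 is recorded in this assay as "not active" (no number reported), without a number, so no step between the two measured compounds can be stated; the two entries only show that compound 2 produces a measurable read-out where compound 1 does not. Compound 3 `COc1ccc(/C=C/C(O)=C/C(=O)c2ccccc2O)cc1OC` has not yet been measured. It differs from compound 2 in one place: hydrogen in place of methoxy on an aromatic carbon. Among the measured compounds shown here, with no step between measured compounds available, the size of this change has to be judged without a precedent; the step from compound 2 to compound 3 is expected to be small, not beyond the scatter, with a slight lean downward. Compound 3 is therefore estimated at 30%, within a range from 5% to 60%, which means an expected a number 10 percentage points lower from compound 2 to compound 3 (within the scatter).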

Compound 3, a percentage reported as inhibition, at one concentration (the size of the read-out at that concentration, not a potency): "not active" (no number reported)
Compound 3: no number reported; the estimate stays without a comparison.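

In this assay, within the data shown here, compound 3 is recorded as "not active" (no number reported) and so no step from compound 2 to compound 3 can be read. No evidence bearing on this result is available. The compounds shown leave open how much the methoxy group contributes to the read-out of compound 2.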